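The source may hold more compounds than are shown below. What is called first, only, known or untested is meant among the compounds shown, and "the series" means these compounds.

Compound 1 `CCOc1ccccc1-c1ccc(-c2nc3cnccc3c(N[C@H](CC)C(N)=O)c2C#N)cc1`: 3
Compound 2 `CCOc1ccccc1-c1ccc(-c2nc3cnccc3c(N[C@@H]3CCOC3=O)c2C#N)cc1`: 2.7
Compound 3 `CCOc1ccccc1-c1ccc(-c2nc3cnccc3c(N[C@H](CC(C)C)C(N)=O)c2C#N)cc1`: 3.4

In a physicochemical assay for lipophilicity, read by HPLC, at pH 7.5 (a lower number here means a more polar compound, a higher number a more lipophilic compound), compound 3 stands highest of the three, with compound 1 nearest and compound 2 furthest; both gaps lie beyond the scatter. Compound 4 `CCOc1ccccc1-c1ccc(-c2nc3cnccc3c(NC(C)C(=O)O)c2C#N)cc1` differs from compound 3 in one place: 1-carboxyethyl in place of 1-carbamoyl-3-methylbutyl on a nitrogen on an aromatic ring. Within the data shown here, of the measured steps, only a number 0.40 log units higher from compound 1 to compound 3 (beyond the scatter) bears on it, touching the chain part of the change alone; no measured pair covers the exchange of carbamoyl for carboxy on this nitrogen, so that part rests on no comparison here. Compound 4 is therefore expected to fall well below compound 3, a step of a number 2.40 log units lower from compound 3 to compound 4 (beyond the scatter) in this assay. The estimate for compound 4 is 1, between 0 and 2.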

Compound 4, distribution coefficient: 2.1
For compound 4 the middle estimate is 1.10 log units below the measured one; measured number above the stated range.
By their numbers in this assay, from the lowest: compound 4; then compounds 2 and 1 (each within the scatter of the next); then compound 3.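

In this assay compound 4 sits lowest of the four, with a number 1.30 log units lower from compound 3 to compound 4 (beyond the scatter) and a number 0.90 log units lower from compound 1 to compound 4 (beyond the scatter) and a number 0.60 log units lower from compound 2 to compound 4 (beyond the scatter) as its steps. Among these compounds, until now this nitrogen had carried only carbamoyl chains and 2-oxooxolan-3-yl, so these steps give the first reading of a carboxy group in this place, and each lies beyond the scatter. On these data alone, each step changes the chain and its end group together, so how much of the drop belongs to each stays open, and a 1-carbamoylethyl group or an amine in this place could separate them. No evidence shown gives a reason for these steps.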